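The compounds below may be only part of what the source reports. "The series", "measured", "known", "first", "only" and "open" are said of these compounds alone.

Measured compounds:
- compound 1 `Cc1nccn1-c1cnc(NCc2c(F)ccc3c2CCO3)c2cn[nH]c(=O)c12`: 7000 nM
- compound 2 `Fc1ccc2c(c1CNc1ncc(Nc3ccccc3)c3nncn13)CCO2`: 3000 nM

Of the compounds shown here, two have been measured in a physicochemical assay for solubility, read by LC-MS, in phosphate buffer, with a stated time of 24 h, at pH 7.4; a lower number here means a less soluble compound, a higher number a more soluble compound. Compound 1 gives 7000 nM, the higher of the two numbers. Compound 2 gives 3000 nM, a number that sits below that of compound 1 by a gap beyond the usual scatter. The two compounds share no single point of difference, so nothing more is said of that pair than what its two values show.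

Compound 3 `Cc1nn(C)cc1-c1cnc(NCc2c(F)ccc3c2CCO3)c2cn[nH]c(=O)c12` has not yet been measured in this assay. It differs from compound 1 in one place: 1,3-dimethyl-1H-pyrazol-4-yl in place of 2-methyl-1H-imidazol-1-yl on an aromatic carbon. The step from compound 1 to compound 3 is thus a swap of one five-membered aromatic ring for another at the same aromatic carbon of the shared core.

Among the measured compounds shown here, no measured pair isolates a change of this kind, so the expectation rests on compound 1 alone. The step is expected to be small and downward, of a size close to the scatter: a 1.6-fold lower number from compound 1 to compound 3 (0.19 log units; within the scatter). Compound 3 is therefore estimated at 4500 nM in this assay, with a range from 1500 nM to 12000 nM.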

Compound 3, solubility: 9000 nM
Compound 3: middle estimate off by 2.0-fold (0.30 log units), on the low side; measured number inside the range.
By their numbers in this assay, from the lowest: compound 2; then compounds 1 and 3 (each within the scatter of the next).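

Among the compounds shown here, compound 1 and compound 3 form the first pair that differs in one place, and in this assay the step is a 1.3-fold higher number from compound 1 to compound 3 (0.11 log units; within the scatter). At this aromatic carbon, ortho to a fused ring and two atoms from the ring nitrogen, the 2-methyl-1H-imidazol-1-yl and 1,3-dimethyl-1H-pyrazol-4-yl groups therefore cannot be told apart in this read-out of solubility, although they are attached through different ring atoms and the entering group has 7 heavy atoms against 6. Nothing available bears on what lies behind this result.

For the compounds shown here, the pair compares only two five-membered aromatic rings with 2 hetero atoms and the same counts of hydrogen-bond donors and acceptors, so it leaves open whether any group of a different kind at this carbon, such as a morpholine, a primary amine or a carboxylic acid, would give a step beyond the scatter. It also leaves open whether the same swap would give a similar step on a different core, since compound 2 shares no single point of difference with either compound.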